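Series notes: the step from compound 2 to compound 4

The compounds below may be only part of what the source reports. "The series", "measured", "known", "first", "only" and "open" are said of these compounds alone.

Measured so far:
Compound 1 `CCCCCCCCCCCCCC[C@H](OCOC)[C@H](CO[Si](c1ccccc1)(c1ccccc1)C(C)(C)C)NC(=O)OC(C)(C)C`: -28%
Compound 2 `CCCCCCCCCCCCCC[C@H](OCOC)[C@H](CO)NC(=O)OC(C)(C)C`: -5.67%
Compound 3 `CCCCCCCCCCCCCC[C@H](OCOC)[C@H](CN(CC)CC)NC(=O)OC(C)(C)C`: 0.84%

In a functional assay on MDA-MB-231 cells (Homo sapiens) for antiproliferative activity, read by sulforhodamine B assay, with a stated time of 48 h, tested at 10 uM (a higher number here means more inhibition at the concentration tested (going by the name of the read-out), a lower number less inhibition), compound 2 gives -5.67%, the second highest of the three numbers. The nearest number is reached by a number 6.5 percentage points higher from compound 2 to compound 3 (within the scatter); the furthest belongs to compound 1 with -28%, a gap beyond the scatter. Compound 4 `CCCCCCCCCCCCCC[C@H](OCOC)[C@H](CN1CCCCC1)NC(=O)OC(C)(C)C` has not been measured. It differs from compound 2 by piperidin-1-yl in place of hydroxy on a saturated chain carbon, two bonds along the chain from an amide-type nitrogen. Going by the values given here, the only step that bears on this is the one to compound 3, diethylamino in place of hydroxy at the same place, which gave a number 6.5 percentage points higher from compound 2 to compound 3 (within the scatter). Another tertiary amine at that place is therefore expected to move the number by no more than the scatter, in no set direction. Compound 4 is estimated at 0%, with a range from -15% to 15%, which means an expected step of a number 5.7 percentage points higher from compound 2 to compound 4 (within the scatter).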

Compound 4, a percentage reported as inhibition, at one concentration (the size of the read-out at that concentration, not a potency): 9.84%
The estimate for compound 4 lay 9.8 percentage points below the measured number; the measured number falls inside the stated range.
By their numbers in this assay, from the lowest: compound 1; then compounds 2, 3 and 4 (each within the scatter of the next, the first and the last beyond it).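

In this assay, replacing hydroxy at this place now gives a step beyond the scatter, a number 15.5 percentage points higher from compound 2 to compound 4 (beyond the scatter), whereas the change to diethylamino stayed within it. The exchange of one tertiary amine for the other, a number 9 percentage points higher from compound 3 to compound 4 (within the scatter), does not separate piperidin-1-yl from diethylamino. Nothing available explains either step. Still open, going by these compounds, is whether morpholin-4-yl or a primary amine at this place would give a number like that of compound 4, and whether a shorter chain would change the picture.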